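This account rests on a few compounds, and the source may have more. Where it says the series, first, only, none or still open, it means among the compounds named here.

Measured so far in an ADME assay on MRC5 cells (Homo sapiens) for cytotoxicity, read by MTT assay, with a stated time of 72 h; on this read-out lower numbers stand for higher toxicity in this test and higher numbers for lower toxicity in this test:
- compound 1 `CCCCCCCCCCCCCCCCCCOP(=O)(O)OC[C@H]1O[C@@H](n2ccc3c(-c4ccccc4)ncnc32)[C@H](O)[C@@H]1O` gives > 50000 nM
- compound 2 `CCCCCCCCCCCCCCCCCCOP(=O)(O)OC[C@H]1O[C@@H](n2ccc3c(-c4ccsc4)ncnc32)[C@H](O)[C@@H]1O` gives > 50000 nM

Compound 2 stands at a limit of this assay, > 50000 nM, and this is not a number. Compound 1 likewise gives only a limit, > 50000 nM. Taken together, the position is the limit of > 50000 nM in this assay, at which 2 of the 2 values shown sit.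

Compound 3 `CCCCCCCCCCCCCCCCCCOP(=O)(O)OC[C@H]1O[C@@H](n2ccc3c(-c4cc5ccccc5o4)ncnc32)[C@H](O)[C@@H]1O` carries 1-benzofuran-2-yl in place of the thiophen-3-yl of compound 2 on an aromatic carbon of the shared core. The counted difference is 1-benzofuran-2-yl in place of thiophen-3-yl on an aromatic carbon.

Within the data shown here, only one measured step bears on this change, a step that the two limits leave unreadable from compound 1 to compound 2, and it gives no size to carry forward. On these data alone, it also replaces one aromatic group with another at the same place. 1-Benzofuran-2-yl itself is untested, so a measurable value for compound 3 remains possible. Even so, no step beyond the scatter is expected in this assay, and compound 3 will most likely report the same limit.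

The expected step is a number no higher from compound 2 to compound 3 (the limit leaves the size open).

For compound 3 the estimated value is 50000 nM.

The expected range for compound 3 runs from 20000 nM to 60000 nM.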

Compound 3, half-maximal cytotoxic concentration: > 50000 nM
Compound 3: only a limit was reported; the forecaster's own chance of this, stated with the estimate: 75%; the middle value sits exactly at the limit.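

Among these compounds, compound 1, compound 2 and compound 3 each report only a limit in this assay and not a number, and no step between them can be read. The compounds shown leave open whether any other group on this aromatic carbon of the shared core gives a measurable value in this assay at all.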